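Removing One Methoxy Group from Compound 2

A few compounds are considered here, and "the series" means these few. Any claim that something is new, unique, unknown or untested is made for them only; others in the source may bear on it.

Of the compounds shown here, three sharing one core have been tested in a functional assay on the whole organism (strain Kunming) with Mus musculus as the target, in the formalin test, with a stated time of 0.5 h; on this read-out lower numbers stand for an effect already at smaller amounts and higher numbers for an effect only at larger amounts of compound. Compound 1 `COc1cc(OC)c(OC)cc1/C=C/COC(=O)/C=C/c1ccc(OC)c(OC)c1` gives 225 umol/kg, compound 2 `COc1cc(OC)c(OC)cc1/C=C/COC(=O)/C=C/c1cc(OC)c(OC)c(OC)c1OC` gives 89 umol/kg, and compound 3 `COc1cc(OC)c(OC)cc1/C=C/COC(=O)/C=C/c1ccccc1C(F)(F)F` gives 291 umol/kg. Compound 2 thus holds the lowest of the three numbers, and its gaps to compound 1 and to compound 3 both lie beyond the usual scatter.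

Compound 4 `COc1cc(OC)c(OC)cc1/C=C/COC(=O)/C=C/c1cc(OC)c(OC)c(OC)c1` has not yet been measured. It differs from compound 2 by one change: hydrogen in place of methoxy on an aromatic carbon.

Going by the values given here, only one measured step changes this part of the molecule: a 1.3-fold higher number from compound 1 to compound 3 (0.11 log units; within the scatter). It replaces 3,4-dimethoxyphenyl with 2-(trifluoromethyl)phenyl and stays within the scatter, so it says little about losing a single methoxy. The two values of compound 1 and compound 2 offer a better guide, though only a rough one. Compound 1 carries fewer methoxy groups on that ring and gives 225 umol/kg, against 89 umol/kg for compound 2. Compound 4 keeps more methoxy groups there than compound 1 and fewer than compound 2, so a modest rise in the number is expected. The estimated change is a 1.6-fold higher number from compound 2 to compound 4 (0.20 log units; within the scatter), a step that may not clear the scatter. For compound 4 the estimate in this assay is 140 umol/kg, with an expected range from 55 umol/kg to 320 umol/kg.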

Compound 4, dose for half-maximal effect: 192 umol/kg
For compound 4 the middle estimate is 1.4-fold (0.14 log units) below the measured one; the range from low to high includes it.
By their numbers in this assay, from the lowest: compound 2; then compounds 4, 1 and 3 (each within the scatter of the next).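

In this assay, going by these compounds alone, there is a 2.2-fold higher number from compound 2 to compound 4 (0.33 log units; beyond the scatter), and this is the first single change on this ring that clears the scatter, since the only earlier step there stayed within it. It shows that the methoxy group ortho to a large group counts for something in compound 2, although the size of the step is modest. Taking the same kind of change at another carbon of the ring gives a different picture, with a 1.2-fold lower number from compound 1 to compound 4 (0.07 log units; within the scatter), so among these compounds swapping one methoxy group and a hydrogen does not shift the number by a clear amount at every place, and no measurement here speaks to why this one carbon differs.

The compounds shown leave open whether the methoxy group itself matters at this carbon or whether another group there, such as a hydroxyl, a fluorine or an ethoxy group, would keep the number near that of compound 2. They also leave open what happens when a methoxy group on a different carbon of this ring leaves compound 2 while the one studied here stays.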